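Removing a benzyl group from a sugar-fused thiopyran series

This account rests on a few compounds, and the source may have more. Where it says the series, first, only, none or still open, it means among the compounds named here.

Measured so far:
Compound 1, `CCOC(=O)C1=C(C)OC2OC(COCc3ccccc3)C(OCc3ccccc3)C(O)C2S1`, gives 12600 nM in an assay on CHO cells for displacement of a labelled ligand from Substance-K receptor (Homo sapiens); a higher number here means a weaker inhibitor, a lower number a stronger inhibitor.
Compound 2, `CCOC(=O)C1=C(C)OC2OC(CO)C(OCc3ccccc3)C(OCc3ccccc3)C2[S+]1[O-]`, gives 4000 nM in this assay.
Compound 3, `CCOC(=O)C1=C(C)OC2OC(CO)C(OCc3ccccc3)C(O)C2S1`, gives > 10000 nM in this assay, which is a limit of the assay rather than a number.

Among the numbers recorded, compound 2 has the lowest one; compound 1 lies a step beyond the usual scatter above it. The difference between the cores of compound 1 and compound 2 is not broken down here.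

Compound 3 arises from compound 1 by one change, (hydrogen in place of benzyl on an oxygen on a saturated carbon). The size of this step, a step that the limit leaves unreadable from compound 1 to compound 3, cannot be read, because compound 3 sits at the limit of > 10000 nM in this assay, at which 1 of the 3 values shown sits.

The unmeasured compound 4, `CCOC(=O)C1=C(C)OC2OC(CO)C(OCc3ccccc3)C(O)C2[S+]1[O-]`, arises from compound 2 by the same kind of change, (hydrogen in place of benzyl on an oxygen on a saturated carbon). The surroundings differ: in compound 1 the oxygen carrying the benzyl sits on a saturated carbon whose other neighbour is a saturated chain carbon, whereas in compound 2 that carbon's other neighbour is a saturated ring carbon.

Among the measured compounds shown here, since the only earlier example of this change is unreadable, the expectation for compound 4 rests loosely on it, and a step of a 2.3-fold higher number from compound 2 to compound 4 (0.35 log units; beyond the scatter) in this assay is expected. For compound 4 a value of 9000 nM is estimated, between 3000 nM and 30000 nM, with a real chance that only a limit is reported.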

Compound 4, inhibition constant: > 10000 nM
Compound 4 was reported as a limit; the forecaster's own chance of this, stated with the estimate: 45%; at least 1.1-fold (0.04 log units) between middle value and limit.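

In this assay compound 4 gives > 10000 nM, which is a limit of the assay and not a number. Even so, the step can be read in one direction: putting hydrogen in place of benzyl on this core gives an at least 2.5-fold higher number from compound 2 to compound 4 (0.39 log units; beyond the scatter), so in this pair, losing the benzyl goes with weaker inhibition by more than the usual scatter. This does not show that the change has the same size on both cores, or even that it carries over from one to the other, and the step on the core of compound 1 cannot be read; one pair with a floor on its size is all there is, because compound 3 and compound 4 both sit at the limit of the assay: the limit of > 10000 nM in this assay, at which 2 of the 4 values shown sit.

The compounds shown leave open whether a group other than benzyl or hydrogen on this oxygen, such as a longer chain ending in a phenyl ring, or a chain carrying an amine or a carboxylic acid, would give a stronger or a weaker inhibitor on either core. They also leave open how large the loss really is, which only a true number for compound 3 and compound 4 could settle.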